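Chain Extension on a Sulfonamide and an Amide

The source may hold more compounds than are shown below. What is called first, only, known or untested is meant among the compounds shown, and "the series" means these compounds.

Compound 1, `CCCCNS(=O)(=O)c1ccc(Nc2ncc3c(n2)N(C2CCCC2)[C@H](CC)C(=O)N3C)cc1`, and compound 2, `CCCNS(=O)(=O)c1ccc(Nc2ncc3c(n2)N(C2CCCC2)[C@H](CC)C(=O)N3C)cc1`, share one core and differ only at the end of a chain. In a functional assay on HeLa cells (Homo sapiens) for antiproliferative activity, read by CCK-8 assay, with a stated time of 72 h (a lower number here means a stronger inhibitor of growth, a higher number a weaker inhibitor of growth), compound 1 gives 451 nM, and in the same assay compound 2 gives 459 nM. The change from compound 2 to compound 1 is methyl in place of hydrogen on a saturated chain carbon, three bonds along the chain from a sulfonamide nitrogen and the resulting step, a 1.0-fold lower number from compound 2 to compound 1 (0.01 log units; within the scatter), lies within the scatter.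

Compound 3, `CCCNC(=O)c1ccc2c(ccn2-c2ncc3c(n2)N(c2ccn(C)n2)C(CC)C(=O)N3C)c1`, is built on a different core; the difference between the two cores is not broken down here. In this assay compound 3 gives 6160 nM, the highest number of the three, standing beyond the scatter from both compound 1 and compound 2.

Compound 4, `CCCCNC(=O)c1ccc2c(ccn2-c2ncc3c(n2)N(c2ccn(C)n2)C(CC)C(=O)N3C)c1`, has not yet been measured in this assay. It differs from compound 3 by methyl in place of hydrogen on a saturated chain carbon, three bonds along the chain from an amide-type nitrogen. This is the same kind of change as that from compound 2 to compound 1, though not the same: the saturated chain carbon sits three bonds along the chain from a sulfonamide nitrogen in the first pair and three bonds along the chain from an amide-type nitrogen in the second.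

The step from compound 3 to compound 4 is expected to be small, a 1.1-fold lower number from compound 3 to compound 4 (0.05 log units; within the scatter), which rests on the earlier pair, where compound 2 to compound 1 gave a 1.0-fold lower number from compound 2 to compound 1 (0.01 log units; within the scatter). Compound 4 is therefore estimated at 5500 nM in this assay, expected to fall between 2500 nM and 12000 nM.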

Compound 4, concentration for 50% growth inhibition: 4260 nM
For compound 4 the middle estimate is 1.3-fold (0.11 log units) above the measured one, within the range that was stated.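

In this assay the lengthening of propyl to butyl on the amide-type nitrogen gives a 1.4-fold lower number from compound 3 to compound 4 (0.16 log units; within the scatter) and so makes no change that can be told from repeat measurement. Set beside the earlier pair, the step on the second core does not differ from the step on the first: the same change on two cores in this assay, a 1.0-fold lower number (0.01 log units; within the scatter) from compound 2 to compound 1 and a 1.4-fold lower number (0.16 log units; within the scatter) from compound 3 to compound 4, 1.4-fold (0.15 log units) apart, within the scatter of two such steps. Among these compounds, this shows that, in these two pairs, the extra methyl at the end of the chain carries over from one core to the other without a measurable effect on growth inhibition, but it rests on only two steps, and since both are small it shows agreement in having no clear effect rather than a gain that transfers; nor does it separate the core from the linking group, as the sulfonamide of the first pair and the amide of the second change together with the rest of the molecule.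

The compounds shown leave open whether a longer chain than butyl, a branched chain such as isobutyl, or a chain ending in an amine or a carboxylic acid would stay as flat at this place. They also leave open whether the same change would behave alike on the sulfonamide and the amide if both were carried on one and the same core.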